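The source may hold more compounds than are shown below. What is called first, only, known or untested is meant among the compounds shown, and "the series" means these compounds.

Measured compounds in an ADME assay on Huh-7 cells (Homo sapiens) for cytotoxicity, read by colorimetric assay; a lower number here means that less compound is tolerated, a higher number that more compound is tolerated:

Compound 1, `COc1ccc2c(O[C@H]3C[C@H]4C(=O)N(C)CCCC/C=C/[C@@H]5C[C@@]5(C(=O)NS(=O)(=O)C5(C)CC5)NC(=O)N4C3)cc(-c3cc(C(C)C)on3)nc2c1Cl`: 75000 nM
Compound 2, `COc1ccc2c(O[C@H]3C[C@H]4C(=O)N(C)CCCC/C=C/[C@@H]5C[C@@]5(C(=O)NS(=O)(=O)C5(C)CC5)NC(=O)N4C3)cc(-c3csc(C(C)C)n3)nc2c1Cl`: 30200 nM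
Compound 3, `COc1ccc2c(O[C@H]3C[C@H]4C(=O)N(C)CCCC/C=C/[C@@H]5C[C@@]5(C(=O)NS(=O)(=O)C5(C)CC5)NC(=O)N4C3)cc(-c3csc(C(F)(F)F)n3)nc2c1Cl`: 59000 nM

On these numbers compound 3 lies between compound 1 and compound 2, and both gaps, a 1.3-fold lower number from compound 1 to compound 3 (0.10 log units; within the scatter) and a 2.0-fold higher number from compound 2 to compound 3 (0.29 log units; within the scatter), are within the scatter. Compound 4, `C#Cc1csc(-c2cc(O[C@H]3C[C@H]4C(=O)N(C)CCCC/C=C/[C@@H]5C[C@@]5(C(=O)NS(=O)(=O)C5(C)CC5)NC(=O)N4C3)c3ccc(OC)c(Cl)c3n2)n1`, has not yet been measured in this assay. The change from compound 3 is 4-ethynyl-1,3-thiazol-2-yl in place of 2-(trifluoromethyl)-1,3-thiazol-4-yl on an aromatic carbon. The two steps that touch this position, from compound 1 and from compound 2 to compound 3, were small, and the larger one, a 2.5-fold lower number from compound 1 to compound 2 (0.40 log units; beyond the scatter), was only modest. The step from compound 3 to compound 4 is therefore expected to stay within the scatter: a 1.1-fold lower number from compound 3 to compound 4 (0.03 log units; within the scatter) is the estimated change. Compound 4 is expected near 55000 nM, in the range 25000 nM to 120000 nM.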

Compound 4, half-maximal cytotoxic concentration: 17000 nM
The estimate for compound 4 lay 3.2-fold (0.51 log units) above the measured number; the measured number lies below the stated range.
By their numbers in this assay, from the lowest: compounds 4, 2, 3 and 1 (each within the scatter of the next, the first and the last beyond it).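

With 4-ethynyl-1,3-thiazol-2-yl at this position, this assay shows a 3.5-fold lower number from compound 3 to compound 4 (0.54 log units; beyond the scatter) and a 4.4-fold lower number from compound 1 to compound 4 (0.64 log units; beyond the scatter), so a swap of one thiazole group for another can carry the number beyond the scatter, though only modestly. The third comparison, a 1.8-fold lower number from compound 2 to compound 4 (0.25 log units; within the scatter), stays within the scatter, so compound 4 cannot be separated from compound 2. No evidence at hand bears on this result. The compounds shown leave open whether the ethynyl group or the thiazol-2-yl attachment drives the step, since both differ at once. They also leave open how a thiazole carrying an amine or a carboxylic acid would behave.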